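The source may report more compounds than this note shows. Statements on the series, on what has been measured and on what is new or still open speak of the compounds shown alone.

Of the compounds shown here, three with a shared core have been measured in an assay on HEK293 cells for inhibition of Voltage-dependent T-type calcium channel subunit alpha-1H (Homo sapiens), read by patch clamp, using a membrane potential dye; on this read-out lower numbers stand for stronger inhibition and higher numbers for weaker inhibition. Compound 1 `CC(C)N1CC2(CCN(C(=O)Nc3ccc(F)c(F)c3)CC2)C1c1ccc(Cl)cc1` gives 174 nM in this assay, and compound 2 `O=C(Nc1cc(F)cc(F)c1)N1CCC2(CC1)C(=O)N(C1CC1)C2c1ccc(Cl)cc1` gives 2260 nM. Compound 3 `COC(=O)[C@H](COC(C)(C)C)NC(=O)N1CCC2(CC1)C(=O)N(c1cccc(F)c1)C2c1ccc(Cl)cc1` gives 251 nM in this assay, the second highest of the three numbers; its nearest neighbour is compound 1, a gap that stays within the usual scatter, and its furthest is compound 2, a gap that goes beyond it.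

Compound 4 `C[C@@H](NC(=O)N1CCC2(CC1)C(=O)N(c1cccc(F)c1)C2c1ccc(Cl)cc1)c1ccccc1` has not yet been measured. It differs from compound 3 in one place: 1-phenylethyl in place of 1-(methoxycarbonyl)-2-(tert-butoxy)ethyl on an amide-type nitrogen, so a group with three hydrogen-bond acceptors and no ring gives way to a group with a six-membered aromatic ring of carbon only and no acceptors. Among the compounds with values here, no pair of measured compounds shows this change, so no step can be read from the numbers. For compound 4 in this assay a value of 150 nM is expected, with a range from 40 nM to 600 nM. The step this estimate means, a 1.7-fold lower number from compound 3 to compound 4 (0.22 log units; within the scatter), is expected to be a small move toward stronger inhibition, not clearly beyond the scatter.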

Compound 4, half-maximal inhibitory concentration: 351 nM
Compound 4: middle estimate off by 2.3-fold (0.37 log units), on the low side; measured number inside the range.
By their numbers in this assay, from the lowest: compounds 1, 3 and 4 (each within the scatter of the next); then compound 2.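

In this assay, putting 1-phenylethyl in place of 1-(methoxycarbonyl)-2-(tert-butoxy)ethyl on the amide-type nitrogen gives a 1.4-fold higher number from compound 3 to compound 4 (0.15 log units; within the scatter). Within the data shown here, this is the first direct test of this place, and it shows that two very different groups can give readings this assay does not separate: one has no ring and three hydrogen-bond acceptors, while the other has a six-membered aromatic ring of carbon only and no acceptors. No measurement shown here accounts for this similarity.

The compounds shown leave open whether this insensitivity extends to other groups on this nitrogen, such as a carboxymethyl group, which carries a carboxylic acid, or a 2-aminoethyl group, which carries an amine. They also leave open whether the mirror-image form of 1-phenylethyl, or a plain benzyl group, would read the same.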